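This account rests on a few compounds, and the source may have more. Where it says the series, first, only, none or still open, it means among the compounds named here.

In a functional assay for activation of Alpha-1D adrenergic receptor (Homo sapiens), read by calcium flux (on this read-out lower numbers stand for an effect already at smaller amounts and higher numbers for an effect only at larger amounts of compound), compound 1 `c1coc(-c2ccccc2OCC2=NCCN2)c1` reaches only a limit of the assay, < 100000 nM. Compound 2 `c1ccc(-c2ccoc2)c(OCC2=NCCN2)c1` gives 5.01 nM in this assay, the only number shown among the two values. The step that the limit leaves unreadable from compound 1 to compound 2 cannot be sized because the limit of < 100000 nM in this assay, at which 1 of the 2 values shown sits, leaves its starting point unreadable. Compound 3 `c1ccc(-c2ccns2)c(OCC2=NCCN2)c1` differs from compound 2 in one place: 1,2-thiazol-5-yl in place of furan-3-yl on an aromatic carbon. Going by the values given here, no measured step of readable size bears on this change, so the expected step of a 3.0-fold higher number from compound 2 to compound 3 (0.48 log units; beyond the scatter) is a guess based only on swapping one five-membered aromatic ring for another. Compound 3 is estimated at 15 nM, with a range from 3 nM to 80 nM.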

Compound 3, half-maximal effective concentration: 25.1 nM
Beside the measured number, compound 3's estimate is 1.7-fold (0.22 log units) below it; the measured number falls inside the stated range.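

In this assay, this place on the aromatic ring now has a step of readable size: 1,2-thiazol-5-yl in place of furan-3-yl gives a 5.0-fold higher number from compound 2 to compound 3 (0.70 log units; beyond the scatter). Compound 3 still gives a number rather than a limit, so two different five-membered aromatic rings give measured values here. The steps starting from compound 1 cannot be read because that compound gives only a limit: the limit of < 100000 nM in this assay, at which 1 of the 3 values shown sits.

On these data alone, it remains open whether the sulfur or the ring nitrogen goes with this step. Also open, as far as these compounds go, is how a plain phenyl ring or an amine would read at this place.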